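This account rests on a few compounds, and the source may have more. Where it says the series, first, only, none or still open, it means among the compounds named here.

Measured compounds:

Compound 1, `COc1cc(-c2cc(/C=C/C(=O)c3ccc(N)cc3)[nH]n2)cc(OC)c1OC`: -52%
Compound 2, `COc1ccc(-c2cc(/C=C/C(=O)c3ccc(N)cc3)[nH]n2)cc1OC`: -76%
Compound 3, `COc1cc(C(=O)/C=C/c2cc(-c3cc(OC)c(OC)c(OC)c3)n[nH]2)cc(OC)c1OC`: -66%

All three were tested in a functional assay on A549 cells (Homo sapiens) for cytotoxicity, read by sulforhodamine B assay, with a stated time of 48 h, tested at 100 uM; a higher number here means a weaker effect of the compound at the concentration tested, a lower number a stronger effect. Compound 1 gives -52% in this assay, compound 2 gives -76%, and compound 3 gives -66%. Compound 1 and compound 2 differ in one place only: hydrogen in place of methoxy on an aromatic carbon. That single change made a step of a number 24 percentage points lower from compound 1 to compound 2 (beyond the scatter). Compound 3 carries a different core; the difference between its core and that of compound 1 is not broken down here. The values of compound 3 and compound 2 lie within the scatter of each other, while compound 3 and compound 1 lie apart by more than the scatter.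

Compound 4, `COc1ccc(-c2cc(/C=C/C(=O)c3cc(OC)c(OC)c(OC)c3)[nH]n2)cc1OC`, has not yet been measured in this assay. It is related to compound 3 by exactly the change that links compound 1 to compound 2: hydrogen in place of methoxy on an aromatic carbon. The place of the change is described in the same words in both pairs, so it is the same change on a different core. Since the step from compound 1 to compound 2 was a number 24 percentage points lower from compound 1 to compound 2 (beyond the scatter), a step of similar direction and size is expected from compound 3 to compound 4, namely a number 19 percentage points lower from compound 3 to compound 4 (beyond the scatter), with the uncertainty that one prior example allows. On that basis compound 4 is estimated to give -85% in this assay, likely between -100% and -65%.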

Compound 4, a percentage reported as activity, at one concentration (the size of the read-out at that concentration, not a potency): -62%
For compound 4 the middle estimate is 23 percentage points below the measured one, and the stated range ends below it.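

In this assay, going by these compounds alone, putting hydrogen in place of methoxy on an aromatic carbon gave a number 4 percentage points higher from compound 3 to compound 4 (within the scatter), so on the core of compound 3 this change produced no step that can be told apart from ordinary variation. Set beside the earlier step, this shows that the effect of the change did not carry from one core to the other in this series: the same change on two cores in this assay, a number 24 percentage points lower (beyond the scatter) from compound 1 to compound 2 and a number 4 percentage points higher (within the scatter) from compound 3 to compound 4, 28 percentage points apart, beyond the scatter of two such steps

Within the data shown here, this does not show why the two cores respond differently, and with only two pairs it cannot say which response would be the more usual one or what the change would do on a third core. Groups other than hydrogen and methoxy at this place on the ring remain open, such as a hydroxyl, a fluorine or a longer chain like ethoxy, so it is unknown whether any of them would behave differently on either core. Each compound also has a read-out at one concentration only, which shows a stronger or weaker effect at that concentration and leaves open how the compounds would compare at other concentrations.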